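Swapping Isopropyl for Methoxyphenyl on the Amide Nitrogen

The source may report more compounds than this note shows. Statements on the series, on what has been measured and on what is new or still open speak of the compounds shown alone.

Three compounds built on a shared core were tested in a functional assay on A549 cells (Homo sapiens) for antiproliferative activity, read by MTT assay, with a stated time of 72 h; a lower number here means a stronger inhibitor, a higher number a weaker inhibitor. Compound 1 `COc1ncc(-c2ccc3c(c2)N(c2ccc(C)cc2)C(=O)CO3)cc1NS(=O)(=O)c1ccc(F)cc1` gives 5870 nM, and compound 2 `CC(C)N1C(=O)COc2ccc(-c3cnc(Cl)c(NS(=O)(=O)c4ccc(F)cc4)c3)cc21` gives 5100 nM. Compound 3 `CC(C)N1C(=O)COc2ccc(-c3cccc(NS(=O)(=O)c4ccc(F)cc4)c3)cc21` gives 29400 nM, the highest of the three numbers and beyond the scatter from both others, so it is the weakest inhibitor among them. Compound 4 `COc1ccc(N2C(=O)COc3ccc(-c4cccc(NS(=O)(=O)c5ccc(F)cc5)c4)cc32)cc1` has not yet been measured. It differs from compound 3 in one place: 4-methoxyphenyl in place of isopropyl on an amide-type nitrogen in a ring. For the measured compounds named here, no pair of measured compounds differs only in this way, so there is no direct guide for the swap. The step of a 2.0-fold lower number from compound 3 to compound 4 (0.29 log units; within the scatter) is expected to run toward a lower number, though it may well stay within the scatter. Compound 4 is estimated at 15000 nM, within a range from 5000 nM to 45000 nM.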

Compound 4, half-maximal inhibitory concentration: 38200 nM
Beside the measured number, compound 4's estimate is 2.5-fold (0.41 log units) below it, within the range that was stated.
By their numbers in this assay, from the lowest: compounds 2 and 1 (each within the scatter of the next); then compounds 3 and 4 (each within the scatter of the next).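

On the amide-type nitrogen in a ring, 4-methoxyphenyl in place of isopropyl gives a 1.3-fold higher number from compound 3 to compound 4 (0.11 log units; within the scatter) in this assay. For the compounds shown here, this is the first pair to isolate this position, and it shows that a ring-bearing group and a branched one can read alike here, with neither ahead of the other. Nothing available explains this likeness.

Going by these compounds, it remains open whether an amine or a carboxylic acid on this nitrogen would shift the number beyond the scatter. The same swap on the other side of the shared core, as in compound 2, is also untested here.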